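This account rests on a few compounds, and the source may have more. Where it says the series, first, only, none or still open, it means among the compounds named here.

Values in a functional assay on A549 cells (Homo sapiens) for inhibition, read by sulforhodamine B assay, with a stated time of 48 h, tested at 50 uM (on this read-out lower numbers stand for less inhibition of growth and higher numbers for more inhibition of growth at the one concentration tested), for the series so far:
compound 1 `COc1cc2c(cc1CC=C(C)C)C(=O)C[C@@H](c1ccc(Oc3ccc(F)cc3)cc1)O2` gives 27%
compound 2 `COc1ccc([C@@H]2C/C(=N/OCc3cn(-c4ccccc4CO)nn3)c3cc(CC=C(C)C)c(OC)cc3O2)cc1` gives 100%

Compound 2 at 100% stands highest of the two numbers, and compound 1 at 27% lies below it, beyond the scatter. For the measured compounds named here, the two compounds differ in more than one place, so no single-place step is available to size the next change.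

Compound 3 `COc1ccc([C@@H]2C/C(=N/OCc3cn(-c4cccnc4Cl)nn3)c3cc(CC=C(C)C)c(OC)cc3O2)cc1` has not yet been measured. It departs from compound 2 in one place, (2-chloropyridin-3-yl in place of 2-(hydroxymethyl)phenyl on an aromatic nitrogen), with 2-chloropyridin-3-yl in place of 2-(hydroxymethyl)phenyl on an aromatic nitrogen of the five-membered aromatic ring with 3 nitrogen.

With compound 2 at 100% as the top number, a step in this assay is expected to go down rather than up. The expected size is given by a number 20 percentage points lower from compound 2 to compound 3 (beyond the scatter), an estimated fall that probably lies beyond the scatter, though with wide uncertainty. The estimate for compound 3 is 80%, with an expected range from 50% to 100% for the measurement.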

Compound 3, percent growth inhibition at one concentration: 58%
Estimate against measurement, compound 3: 22 percentage points above; low and high end bracket the measured number.
By their numbers in this assay, from the lowest: compound 1; then compound 3; then compound 2.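

In this assay, for the compounds shown here, the group on the aromatic nitrogen of the five-membered aromatic ring with 3 nitrogen proves to be a position that moves the read-out: 2-chloropyridin-3-yl in place of 2-(hydroxymethyl)phenyl gives a number 42 percentage points lower from compound 2 to compound 3 (beyond the scatter), a large step and the first single-place comparison. The step does not remove the effect, as compound 3 still gives 58%, but the change bundles the loss of the hydroxymethyl hydrogen-bond donor, a ring nitrogen and a chlorine, so the numbers cannot assign the fall to any one of these. Nothing at hand bears on why the read-out falls at this position.

Still open, going by these compounds, is which part of the change carries the step: a plain phenyl, a pyridine ring bearing hydroxymethyl, or an amine or a carboxylic acid in place of the hydroxymethyl would each separate these parts. With a reading at one concentration only, the step also leaves open how compound 2 and compound 3 compare across a range of concentrations.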